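The source may hold more compounds than are shown below. What is called first, only, known or untested is meant among the compounds shown, and "the series" means these compounds.

Values so far in a functional assay on HepG2 cells (Homo sapiens) for antiproliferative activity, read by MTT assay (a higher number here means a weaker inhibitor, a lower number a stronger inhibitor), are:
- compound 1 `CC1(C)CCc2cc(C(=O)/C=C/c3ccc(OCc4cn(-c5ccc(Cl)cc5)nn4)cc3)c(O)cc2O1` gives "not active" (no number reported)
- compound 2 `CCc1ccccc1-n1cc(COc2ccc(/C=C/C(=O)c3cc4c(cc3O)OC(C)(C)CC4)cc2)nn1` gives 115000 nM

Within the data shown here, compound 2 holds the only number, and with compound 1 reported without a figure, there is no second number to rank it against. Compound 3 `Cc1ccc(-n2cc(COc3ccc(/C=C/C(=O)c4cc5c(cc4O)OC(C)(C)CC5)cc3)nn2)cc1Br` has not yet been measured in this assay and keeps the core of compound 2. The change sits on an aromatic nitrogen of the five-membered aromatic ring with 3 nitrogen: 3-bromo-4-methylphenyl in place of 2-ethylphenyl on an aromatic nitrogen with the rest of the structure the same.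

Among the measured compounds shown here, the series contains no step between measured compounds, so the data give no measure of what a change at this place does. The expectation is therefore no step beyond the scatter, in either direction, and the estimated change is a 1.3-fold lower number from compound 2 to compound 3 (0.11 log units; within the scatter) as a working figure. A report without a number, as for compound 1 with "not active" (no number reported) as its entry, also remains possible. The estimate for compound 3 is 90000 nM with an expected range of 30000 nM to 250000 nM if a number is obtained.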

Compound 3, half-maximal inhibitory concentration: 117000 nM
Compound 3: the middle estimate sits 1.3-fold (0.11 log units) below what was measured, within the range that was stated.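

In this assay, among these compounds, 3-bromo-4-methylphenyl in place of 2-ethylphenyl on an aromatic nitrogen gives a 1.0-fold higher number from compound 2 to compound 3 (0.01 log units; within the scatter), the first step that can be read at this position. The two groups, each of 8 heavy atoms with one six-membered aromatic ring of carbon only, are not separated by this read-out, so this one exchange of substituents on the phenyl ring leaves the number unmoved, while any step involving compound 1, which gives "not active" (no number reported), cannot be read. No measurement at hand bears on this result.

Going by these compounds, the position is described by a single readable pair, so it remains open whether this flat result holds for other groups on the aromatic nitrogen or only for these two. A phenyl ring carrying an amine or a carboxylic acid, or a longer chain in place of the ethyl, would test whether anything at this position moves the number in this assay beyond the scatter.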